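Bromine on the benzylidene ring of the acetoxy chalcone analogue

The source may hold more compounds than are shown below. What is called first, only, known or untested is meant among the compounds shown, and "the series" means these compounds.

The series rests on three measured compounds: compound 1 `O=C(/C(=C/c1ccccc1)CCl)c1ccccc1`, compound 2 `O=C(/C(=C/c1ccc(Cl)cc1Cl)CCl)c1ccccc1` and compound 3 `CC(=O)OC/C(=C\c1ccccc1)C(=O)c1ccccc1`. In a functional assay on T47D cells (Homo sapiens) for inhibition, read by sulforhodamine B assay, with a stated time of 48 h (a lower number here means a stronger inhibitor of growth, a higher number a weaker inhibitor of growth), compound 1 gives 18000 nM, compound 2 gives 6300 nM and compound 3 gives 16000 nM. Compound 3 thus stands second highest of the three numbers; its nearest neighbour is compound 1, whose value lies within the scatter of it, while compound 2 is the furthest, with a lower number beyond the scatter. Within the data shown here, the one single-site step, a 1.1-fold lower number from compound 1 to compound 3 (0.05 log units; within the scatter), shows that replacing the chloro by the acetoxy group hardly moves the number.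

Compound 4 `CC(=O)OC/C(=C\c1ccccc1Br)C(=O)c1ccccc1` carries bromo in place of hydrogen on an aromatic carbon. Among the measured compounds shown here, no measured step covers exactly this change. For the measured compounds named here, the only guide is the pair compound 1 and compound 2, which differ by two chloro groups on the same ring and whose values show a lower number for the dichloro compound, beyond the scatter. A single bromo is a smaller change, so a step for compound 4 of about the size a 2.0-fold lower number from compound 3 to compound 4 (0.30 log units; within the scatter) is expected, toward a lower number but near the edge of the scatter. Compound 4 is therefore estimated in this assay at 8000 nM, within a range of 3000 nM to 20000 nM.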

Compound 4, concentration for 50% growth inhibition: 17000 nM
Beside the measured number, compound 4's estimate is 2.1-fold (0.33 log units) below it, within the range that was stated.
By their numbers in this assay, from the lowest: compound 2; then compounds 3, 4 and 1 (each within the scatter of the next).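

In this assay, among these compounds, the step of a 1.1-fold higher number from compound 3 to compound 4 (0.03 log units; within the scatter) is the first reading of a group placed on the aromatic ring of the acetoxy series, on an aromatic carbon ortho to a large group. By this reading, compound 3 and compound 4 cannot be told apart, so a single bromo at this place, with the acetoxy group kept, leaves no effect that can be separated from the scatter. The result covers this one place and this one group only, and no measurement shown gives a reason for it.

The compounds shown leave open whether a different group on the same aromatic carbon, such as an amine, a methoxy group or a carboxylic acid, would also stay within the scatter of compound 3. They also leave open whether bromo on another carbon of the ring would read the same, and whether a longer chain in place of the acetyl part of the acetoxy group would move the number in this series.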